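This account rests on a few compounds, and the source may have more. Where it says the series, first, only, none or still open, it means among the compounds named here.

The measured compounds in a functional assay on SK-OV-3 cells (Homo sapiens) for inhibition, read by CCK-8 assay, with a stated time of 70 h; a lower number here means a stronger inhibitor, a higher number a weaker inhibitor:

Compound 1, `Clc1ccc(COc2ccc(OCCOCCNC3CCCC3)cc2)cc1`: 7670 nM
Compound 2, `O=[N+]([O-])c1cccc(COc2ccc(OCCOCCNC3CCCC3)cc2)c1`: 15400 nM
Compound 3, `COc1ccc(OCCOCCNC2CCCC2)cc1`: 99100 nM

Compound 3 gives the highest number of the three: a 6.4-fold higher number from compound 2 to compound 3 (0.81 log units; beyond the scatter) and a 13-fold higher number from compound 1 to compound 3 (1.11 log units; beyond the scatter). The two compounds bearing an aryl group at that position sit close to one another, a 2.0-fold higher number from compound 1 to compound 2 (0.30 log units; within the scatter).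

Compound 4, `CCOc1ccc(OCCOCCNC2CCCC2)cc1`, differs from compound 3 by methyl in place of hydrogen on a saturated chain carbon bound to an oxygen on an aromatic ring. Among the compounds with values here, no measured pair tests this exact change. What the data show is that placing a 4-chlorophenyl or a 3-nitrophenyl on this saturated chain carbon gives a much lower number than hydrogen, as the steps from compound 1 and compound 2 to compound 3 record. A methyl is a far smaller addition at the same carbon, so only a small part of that difference, if any, is expected to appear, and a step near the scatter in this assay is the likely outcome.

Compound 4 is therefore expected to give 70000 nM, with a range from 30000 nM to 160000 nM. That estimate means an expected step of a 1.4-fold lower number from compound 3 to compound 4 (0.15 log units; within the scatter).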

Compound 4, half-maximal inhibitory concentration: 90500 nM
The estimate for compound 4 lay 1.3-fold (0.11 log units) below the measured number, and the stated range covers the measured number.
By their numbers in this assay, from the lowest: compounds 1 and 2 (each within the scatter of the next); then compounds 4 and 3 (each within the scatter of the next).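

In this assay, going from the methoxy of compound 3 to the ethoxy of compound 4 leaves the number in place (a 1.1-fold lower number from compound 3 to compound 4 (0.04 log units; within the scatter)), so a methyl on this saturated chain carbon does not reproduce what the aryl groups do there. The two aryl compounds stand as far from the ethoxy compound as from the methoxy one (a 5.9-fold higher number from compound 2 to compound 4 (0.77 log units; beyond the scatter); a 12-fold higher number from compound 1 to compound 4 (1.07 log units; beyond the scatter)), so among these compounds the lower numbers go only with the 3-nitrophenyl and 4-chlorophenyl groups. Nothing measured here accounts for the gap between a methyl and these aryl groups.

The compounds shown leave open whether a longer chain, such as propyl or butyl, on this carbon would lower the number at all. They also leave open whether an unsubstituted phenyl or a cyclohexyl would match the two substituted phenyl groups.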